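Compound 3: swapping the benzyl group at the tolerance limit

The compounds below may be only part of what the source reports. "The series", "measured", "known", "first", "only" and "open" are said of these compounds alone.

Measured in an ADME assay on MDBK cells (Bos taurus) for cytotoxicity; a higher number here means that more compound is tolerated, a lower number that less compound is tolerated:
compound 1 `Fc1cccc(F)c1Cn1c(-c2c(F)cccc2F)nc2ccncc21`: 99000 nM
compound 2 `COc1cccc(Cn2ccc3nc(-c4ccccc4)nc-3c2)c1`: > 100000 nM

Compound 2 gives > 100000 nM, which is a limit of the assay and not a number. It therefore marks no exact position, and (the limit of > 100000 nM in this assay, at which 1 of the 2 values shown sits). Compound 1 gives a measured number, 99000 nM. Among the measured compounds shown here, no step between measured compounds differing in one place is available to scale the next change.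

Compound 3 `Brc1ccccc1Cn1ccc2nc(-c3ccccc3)nc-2c1` carries 2-bromophenyl in place of 3-methoxyphenyl on a saturated chain carbon bound to an aromatic nitrogen. No change beyond the usual scatter is expected in this assay, in either direction. This expectation leans on compound 1, which gives 99000 nM with a different structure. A number is expected to be about as likely as a limit for compound 3.

The expected change is an at least 1.1-fold lower number from compound 2 to compound 3 (0.04 log units; that floor lies within the scatter). For compound 3 the estimated half-maximal cytotoxic concentration is 90000 nM, with an expected range of 40000 nM to 150000 nM.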

Compound 3, half-maximal cytotoxic concentration: > 100000 nM
Compound 3: a limit, no number; the forecaster's own chance of this, stated with the estimate: 50%; at least 1.1-fold (0.04 log units) between middle value and limit.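

No step can be read between compound 2 and compound 3, since both stand at a limit of the assay and neither gives a number: the limit of > 100000 nM in this assay, at which 2 of the 3 values shown sit.

Open, on these data alone, is whether 2-bromophenyl and 3-methoxyphenyl, on a saturated chain carbon bound to an aromatic nitrogen, differ at all in this assay.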